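Swapping a Cyclohexylamino Group for Methyl on a Sugar Conjugate

The source may report more compounds than this note shows. Statements on the series, on what has been measured and on what is new or still open speak of the compounds shown alone.

Of the compounds shown here, three have been tested in an ADME assay on HepG2 cells (Homo sapiens) for cytotoxicity, read by MTT assay, with a stated time of 48 h; a lower number here means that less compound is tolerated, a higher number that more compound is tolerated. Compound 1 `C#CCN(c1nc(-c2cccc(Br)c2)no1)C1CCCCC1` gives 53.5 ug/mL. Among the measured compounds shown here, compound 3 `C#CCN(c1nc(-c2cccc([N+](=O)[O-])c2)no1)C1CCCCC1` gives 45.5 ug/mL; the only one-step change among the measured compounds, a 1.2-fold lower number from compound 1 to compound 3 (0.07 log units; within the scatter), is a small shift. Compound 2 `CC(=O)OC[C@H]1O[C@H](OC[C@H](Cn2cc(COc3ccc(-c4noc(NC5CCCCC5)n4)cc3)nn2)OC(C)=O)C=C[C@@H]1OC(C)=O` gives 99.5 ug/mL, the highest of the three numbers: the gap to compound 3 lies beyond the usual scatter, while the value of compound 1 lies within scatter of it.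

Compound 4 `CC(=O)OC[C@H]1O[C@H](OC[C@H](Cn2cc(COc3ccc(-c4noc(C)n4)cc3)nn2)OC(C)=O)C=C[C@@H]1OC(C)=O` differs from compound 2 only by methyl in place of cyclohexylamino on an aromatic carbon. For the measured compounds named here, the single measured step, the nitro-for-bromo swap, concerns a different part of a different scaffold and says nothing about removing a cyclohexylamino group from the five-membered ring, so no measured step bears on this change. With nothing to point either way, the expectation is that the step of a 1.1-fold lower number from compound 2 to compound 4 (0.04 log units; within the scatter) stays within the scatter, and compound 4 is expected to give about 90 ug/mL, with a range from 45 ug/mL to 180 ug/mL.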

Compound 4, half-maximal cytotoxic concentration: 37.7 ug/mL
Compound 4: the middle estimate sits 2.4-fold (0.38 log units) above what was measured, outside the stated range (below it).
By their numbers in this assay, from the lowest: compounds 4, 3, 1 and 2 (each within the scatter of the next, the first and the last beyond it).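

In this assay, putting methyl in place of cyclohexylamino on the sugar conjugate gives a 2.6-fold lower number from compound 2 to compound 4 (0.42 log units; beyond the scatter), so less compound is tolerated once this group is gone. The group on this carbon of the five-membered ring therefore counts in this pair, whereas the nitro-for-bromo swap, made elsewhere on a different scaffold, gave only a 1.2-fold lower number from compound 1 to compound 3 (0.07 log units; within the scatter). No measurement shown explains why the number falls with this change.

The swap removes the six-membered carbon ring and the linking nitrogen together, so the compounds shown cannot separate the two; a plain amino group or a cyclohexyl ring attached directly to the carbon would pull them apart. Going by these compounds, whether the same swap has a similar result on the core of compound 1 also remains open.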